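The source may hold more compounds than are shown below. What is called first, only, known or untested is meant among the compounds shown, and "the series" means these compounds.

Measured so far:
- Compound 1 `COc1cc2ncnc(Nc3ccc(Cl)c(C(F)(F)F)c3)c2cc1OCCCCC(=O)Nc1ccc(S(N)(=O)=O)cc1`, 3220 nM in a functional assay on NCI-H1975 cells (Homo sapiens) for antiproliferative activity, read by MTT assay, with a stated time of 72 h; on this read-out lower numbers stand for stronger inhibition and higher numbers for weaker inhibition
- Compound 2 `COc1cc2ncnc(Nc3cc(F)c(F)c(F)c3)c2cc1OCCCCC(=O)Nc1ccc(S(N)(=O)=O)cc1`, 20000 nM
- Compound 3 `C#Cc1cccc(Nc2ncnc3ccc(NC(=S)Nc4ccc(S(N)(=O)=O)cc4)cc23)c1`, 13400 nM

Among these three numbers, compound 3 sits second highest: its value and that of compound 2 lie within the scatter of each other, so neither can be called weaker, while compound 1 stands clearly lower. Compound 4 `NS(=O)(=O)c1ccc(NC(=S)Nc2ccc3ncnc(Nc4ccc(Cl)c(C(F)(F)F)c4)c3c2)cc1` is yet to be measured. It differs from compound 3 in one place: 4-chloro-3-(trifluoromethyl)phenyl in place of 3-ethynylphenyl on a nitrogen on an aromatic ring.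

Going by the values given here, the only measured step that touches this position is a 6.2-fold higher number from compound 1 to compound 2 (0.79 log units; beyond the scatter), which shows that swapping the group on that nitrogen can shift the number well beyond the scatter. There compound 1 carries the same 4-chloro-3-(trifluoromethyl)phenyl that enters in compound 4, and compound 1 has the lowest number measured. Among the compounds with values here, no step compares 3-ethynylphenyl directly with this group, and compound 1 also differs from compound 3 in its linking chain, so the transfer is uncertain. A modest step toward a lower number is therefore expected, a 2.2-fold lower number from compound 3 to compound 4 (0.35 log units; beyond the scatter). Compound 4 is estimated at 6000 nM, likely between 1500 nM and 25000 nM.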

Compound 4, half-maximal inhibitory concentration: 11800 nM
The estimate for compound 4 lay 2.0-fold (0.29 log units) below the measured number; low and high end bracket the measured number.
By their numbers in this assay, from the lowest: compound 1; then compounds 4, 3 and 2 (each within the scatter of the next).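

In this assay the exchange on the nitrogen gives a 1.1-fold lower number from compound 3 to compound 4 (0.06 log units; within the scatter), so with this linking chain, 4-chloro-3-(trifluoromethyl)phenyl and 3-ethynylphenyl cannot be told apart. The earlier step showed that a swap at this position can move the number beyond the scatter, whereas this one shows that a swap here can also leave it unresolved, even though the entering group is larger by count of heavy atoms. No measurement at hand explains this result.

Still open, on these data alone, is whether the two groups would also sit level on the longer chain of compound 1, which would need a 3-ethynylphenyl partner for that compound. Also open, as far as these compounds go, is how this nitrogen would respond to a plain phenyl, or to a phenyl carrying an amine or a carboxylic acid.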